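A few compounds are considered here, and "the series" means these few. Any claim that something is new, unique, unknown or untested is made for them only; others in the source may bear on it.

Compounds measured so far:
- Compound 1 `COc1ccccc1-c1oc2ccc(NC(C)=O)cc2c(=O)c1O`: 385000 nM
- Compound 2 `COc1c(-c2ccccc2)oc2ccc(NC(C)=O)cc2c1=O`: 200000 nM

Both numbers come from an ADME assay on MT4 cells (Homo sapiens) for cytotoxicity, read by MTT assay, with a stated time of 4 days; on this read-out higher numbers stand for lower toxicity in this test and lower numbers for higher toxicity in this test. Compound 2 stands at 200000 nM, while compound 1 stands at 385000 nM. These two values lie within the usual scatter of repeated measurements, so they cannot be placed in any order.

Compound 3 `COc1ccccc1-c1oc2ccc(NC(C)=O)cc2c(=O)c1OC` has not yet been measured. It differs from compound 2 by a single change: methoxy in place of hydrogen on an aromatic carbon. In words, this is methoxy in place of hydrogen on an aromatic carbon, ortho to a large group, which turns phenyl into 2-methoxyphenyl.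

Going by the values given here, no measured pair shows this change on its own, so the data give no direct guide to its size. Among the compounds with values here, the only guide is the narrow spread of the two known values, compound 2 at 200000 nM and compound 1 at 385000 nM. On that basis, no step beyond the scatter is expected in this assay, and the expected 1.3-fold higher number from compound 2 to compound 3 (0.10 log units; within the scatter) is small. Compound 3 is estimated at 250000 nM, with an expected range from 100000 nM to 500000 nM.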

Compound 3, half-maximal cytotoxic concentration: 154000 nM
Compound 3: middle estimate off by 1.6-fold (0.21 log units), on the high side; measured number inside the range.
By their numbers in this assay, from the lowest: compounds 3, 2 and 1 (each within the scatter of the next, the first and the last beyond it).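

Turning phenyl into 2-methoxyphenyl, with methoxy in place of hydrogen on an aromatic carbon ortho to a large group, gives a 1.3-fold lower number from compound 2 to compound 3 (0.11 log units; within the scatter) in this assay, so this first direct look at the change shows no effect that can be told apart from repeat-measurement noise. The second comparison concerns the oxygen on the shared core, where methyl in place of hydrogen gives a 2.5-fold lower number from compound 1 to compound 3 (0.40 log units; beyond the scatter); this modest step is the only one here beyond the scatter, and since lower numbers stand for higher toxicity in this test, capping that oxygen goes with a small rise in measured toxicity. Nothing measured here explains either step.

What the compounds shown leave open is whether a different group at the same ring place, such as an amine or a carboxylic acid, would give a step beyond the scatter. They also leave open whether a longer chain on the oxygen, such as ethyl or propyl in place of methyl, would carry the modest step further or leave it unchanged.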